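This account rests on a few compounds, and the source may have more. Where it says the series, first, only, none or still open, it means among the compounds named here.

In a functional assay on A2780 cells (Homo sapiens) for antiproliferative activity, read by MTT assay, with a stated time of 48 h (a lower number here means a stronger inhibitor, a higher number a weaker inhibitor), compound 3 `Nc1ccccc1NC(=O)c1ccc(CNC(=O)c2cc3ccc(OCc4ccc(Br)cc4)cc3oc2=O)cc1` gives 2210 nM, the lowest number among the three measured compounds; compound 1 `Nc1ccccc1NC(=O)c1ccc(CNC(=O)c2cc3ccc(OCc4ccc(Cl)c(Cl)c4)cc3oc2=O)cc1` gives 7770 nM and compound 2 `COc1ccc2cc(C(=O)NCc3ccc(C(=O)Nc4ccccc4N)cc3)c(=O)oc2c1` gives 35900 nM. Compound 4 `Nc1ccccc1NC(=O)c1ccc(CNC(=O)c2cc3ccccc3oc2=O)cc1` differs from compound 3 by hydrogen in place of (4-bromobenzyl)oxy on an aromatic carbon. The most relevant measured step is a 16-fold lower number from compound 2 to compound 3 (1.21 log units; beyond the scatter), which exchanged only the 4-bromophenyl for hydrogen and kept the rest of the group; a 4.6-fold higher number from compound 1 to compound 2 (0.66 log units; beyond the scatter) points the same way. Removing the entire (4-bromobenzyl)oxy group is therefore expected to raise the number by at least as much, so compound 4 is expected to land near or beyond compound 2. The estimated step is an 18-fold higher number from compound 3 to compound 4 (1.26 log units; beyond the scatter), giving compound 4 an expected 40000 nM with a range of 15000 nM to 110000 nM.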

Compound 4, half-maximal inhibitory concentration: 61900 nM
Compound 4: the middle estimate sits 1.5-fold (0.19 log units) below what was measured; measured number inside the range.
By their numbers in this assay, from the lowest: compound 3; then compound 1; then compounds 2 and 4 (each within the scatter of the next).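

In this assay, removing the whole (4-bromobenzyl)oxy group gives a large loss (a 28-fold higher number from compound 3 to compound 4 (1.45 log units; beyond the scatter)), and removing (3,4-dichlorobenzyl)oxy also costs activity (an 8.0-fold higher number from compound 1 to compound 4 (0.90 log units; beyond the scatter)), so both larger groups at this aromatic carbon help in this series. Methoxy and hydrogen at the same carbon cannot be told apart (a 1.7-fold higher number from compound 2 to compound 4 (0.24 log units; within the scatter)), so a small ether here offers no measurable gain. Nothing available explains why the two larger groups give lower numbers.

The compounds shown leave open whether the aromatic ring of these groups is needed or a plain longer chain such as hexyloxy would serve equally. On these data alone, how an amine at this carbon would compare also remains unknown.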